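This account rests on a few compounds, and the source may have more. Where it says the series, first, only, none or still open, it means among the compounds named here.

Compound 1 `CCCC1(c2ccccc2)NC(=O)N(Cc2ccc(C(=O)NO)cc2)C1=O` and compound 2 `COc1ccc(CC2(c3ccccc3)NC(=O)N(Cc3ccc(C(=O)NO)cc3)C2=O)cc1` share the same core and differ in a single place: compound 2 carries 4-methoxyphenyl in place of ethyl on a saturated chain carbon bound to a saturated ring carbon. In an assay on isolated protein for inhibition of protein deacetylase HDAC6 (Homo sapiens), read by fluorescence, with stated times of 10 min and 2 h (on this read-out lower numbers stand for stronger inhibition and higher numbers for weaker inhibition), compound 1 gives 50.9 nM, and in this assay compound 2 gives 72.4 nM. On these two numbers compound 2 has the higher one, but the step of a 1.4-fold higher number from compound 1 to compound 2 (0.15 log units; within the scatter) lies within the scatter, so the two compounds cannot be told apart by this measurement.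

Compound 3 `O=C(NO)c1ccc(CN2C(=O)NC(Cc3ccc4ccccc4c3)(c3ccccc3)C2=O)cc1` is the next change at the same place: naphthalen-2-yl in place of 4-methoxyphenyl on a saturated chain carbon bound to a saturated ring carbon. Within the data shown here, the only measured step that touches this position is a 1.4-fold higher number from compound 1 to compound 2 (0.15 log units; within the scatter), which showed that replacing a small group by a six-membered aromatic ring with an oxygen made no difference beyond the scatter. A larger aromatic group without that oxygen is therefore expected to leave the number near where compound 2 sits, with the step of a 1.0-fold lower number from compound 2 to compound 3 (0.01 log units; within the scatter) expected to stay within the scatter. For compound 3 the estimate in this assay is 70 nM, within a range of 30 nM to 170 nM.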

Compound 3, half-maximal inhibitory concentration: 74.6 nM
Estimate against measurement, compound 3: 1.1-fold (0.03 log units) below; the range from low to high includes it.
By their numbers in this assay, from the lowest: compounds 1, 2 and 3 (each within the scatter of the next).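

Going from compound 2 to compound 3 removes the oxygen of 4-methoxyphenyl, along with its one hydrogen-bond acceptor, and brings in naphthalen-2-yl, with 2 six-membered aromatic rings of carbon only in place of one. Even so, this assay shows a 1.0-fold higher number from compound 2 to compound 3 (0.01 log units; within the scatter), so this change of ring system and loss of oxygen cannot be detected in this measurement. The wider comparison, a 1.5-fold higher number from compound 1 to compound 3 (0.17 log units; within the scatter), spans ethyl and naphthalen-2-yl at the saturated chain carbon bound to a saturated ring carbon and also stays within the scatter, which means that all three compounds remain indistinguishable here despite the difference in the size of these groups; no other measurement is available to account for this result.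

Going by these compounds, all the groups compared at this place are uncharged and carry no hydrogen-bond donor, so it remains open whether an amine or a carboxylic acid there would shift the number beyond the scatter. A longer chain of carbon atoms ending in naphthalen-2-yl is likewise an untested question in the compounds shown here.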